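Chain-end group swap on the longer chain: compound 4

The source may hold more compounds than are shown below. What is called first, only, known or untested is meant among the compounds shown, and "the series" means these compounds.

Compound 1 `CN(C)/C(=N/CCCCn1nc(-c2ccccc2)ccc1=O)NC#N`, compound 2 `CC/N=C(/NC#N)NCCCCn1nc(-c2ccccc2)ccc1=O` and compound 3 `CC/N=C(/NC#N)NCCCCCn1nc(-c2ccccc2)ccc1=O` are measured. In a functional assay on the whole organism (stomach) with Rattus norvegicus as the target (a higher number here means that more compound is needed for the effect, a lower number that less compound is needed), compound 1 gives 30.3 mg/kg, compound 2 gives 92 mg/kg and compound 3 gives 100 mg/kg; the numbers of compound 2 and compound 3 lie within the scatter of each other. The difference between the cores of compound 2 and compound 3 is not broken down here. Within the core of compound 2 the change a group of 8 heavy atoms (4 carbon, 4 nitrogen; no ring) in place of a group of 8 heavy atoms (4 carbon, 4 nitrogen; no ring), on a saturated chain carbon, four bonds along the chain from an aromatic nitrogen gives the step of a 3.0-fold lower number from compound 2 to compound 1 (0.48 log units; beyond the scatter). Compound 4 `CN(C)/C(=N/CCCCCn1nc(-c2ccccc2)ccc1=O)NC#N` is not yet measured; it carries the same kind of change on the core of compound 3, (a group of 8 heavy atoms (4 carbon, 4 nitrogen; no ring) in place of a group of 8 heavy atoms (4 carbon, 4 nitrogen; no ring), on a saturated chain carbon, five bonds along the chain from an aromatic nitrogen), the place being five bonds along the chain from an aromatic nitrogen rather than four. Within the data shown here, a step of similar size, a 3.0-fold lower number from compound 3 to compound 4 (0.48 log units; beyond the scatter), is expected because the earlier step of a 3.0-fold lower number from compound 2 to compound 1 (0.48 log units; beyond the scatter) is the only guide to this change. Compound 4 is therefore estimated at 33 mg/kg, with a range from 15 mg/kg to 75 mg/kg.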

Compound 4, dose for half-maximal effect: 81.5 mg/kg
Compound 4: middle estimate off by 2.5-fold (0.39 log units), on the low side; the whole stated range lies below it.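

On the core of compound 3 the swap gives a 1.2-fold lower number from compound 3 to compound 4 (0.09 log units; within the scatter) in this assay and so shows no clear effect on that core taken alone. Set beside the step on the shorter chain, the two steps do not clearly differ: the same change on two cores in this assay, a 3.0-fold lower number (0.48 log units; beyond the scatter) from compound 2 to compound 1 and a 1.2-fold lower number (0.09 log units; within the scatter) from compound 3 to compound 4, 2.5-fold (0.39 log units) apart, within the scatter of two such steps
This is compatible with the change carrying over between the two cores, but it does not show that the step keeps its size; one step lies beyond the scatter and the other within it, and two cores cannot settle any dependence on chain length.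

The compounds shown leave open how the swap behaves on a shorter or a longer chain. Also open, from the compounds shown here alone, is whether a urea or an amine at the chain end would change the dose needed.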